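Ethoxy Shift Gains, Then a Sulfonamide Replaces Methoxy

The compounds below may be only part of what the source reports. "The series", "measured", "known", "first", "only" and "open" are said of these compounds alone.

Measured compounds in a functional assay on the whole organism (strain Sprague-Dawley) for inhibition, with Rattus norvegicus as the target, with a stated time of 10 min; a lower number here means that less compound is needed, a higher number that more compound is needed for the effect:
compound 1 `COc1ccc(OC)c(-c2ncc(C(=O)O)c(=O)[nH]2)c1` gives 1 mg/kg
compound 2 `CCOc1ccc(OC)cc1-c1ncc(C(=O)O)c(=O)[nH]1` gives 0.2 mg/kg

Within the data shown here, compound 2 has the lowest number of the two measured so far in this assay; its nearest neighbour is compound 1, and the step of a 5.0-fold lower number from compound 1 to compound 2 (0.70 log units; beyond the scatter) lies beyond the scatter. That step arose from methyl in place of hydrogen on a saturated chain carbon bound to an oxygen on an aromatic ring, so it concerns the ethoxy group, not the position altered next.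

Compound 3 `CCOc1ccc(S(=O)(=O)N(C)C)cc1-c1ncc(C(=O)O)c(=O)[nH]1` keeps the ethoxy group and the shared core of compound 2 and changes only one place: dimethylsulfamoyl in place of methoxy on an aromatic carbon

Among the measured compounds shown here, no measured step touches this aromatic carbon, so the single step in this assay gives no direct guide to the size or direction of the change. With the methoxy group of compound 1 and compound 2 replaced by dimethylsulfamoyl para to the ethoxy group, compound 3 is expected to give a number close to compound 2, with the expected step of a 1.5-fold higher number from compound 2 to compound 3 (0.18 log units; within the scatter) not clearly beyond the scatter. For compound 3 the estimated value is 0.3 mg/kg, in the range 0.08 mg/kg to 1.2 mg/kg.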

Compound 3, dose for 50% inhibition: > 50 mg/kg
Compound 3 gave a limit, no number (the forecaster's own chance of this, stated with the estimate: 10%); middle value at least 160-fold (2.22 log units) from the limit.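

In this assay, the aromatic carbon para to an ethoxy group proved highly sensitive to what it carries: with the ethoxy group and the shared core kept, dimethylsulfamoyl in place of methoxy gave an at least 250-fold higher number from compound 2 to compound 3 (2.39 log units; beyond the scatter). Compound 3 gives a limit of the assay and not a number: the limit of > 50 mg/kg in this assay, at which 1 of the 3 values shown sits. The earlier step, a 5.0-fold lower number from compound 1 to compound 2 (0.70 log units; beyond the scatter), had shown only how the number moves with the ethoxy group; this change at another place moves it much further and in the opposite direction, so keeping the ethoxy group did not preserve the low number of compound 2.

The compounds shown leave open whether the whole sulfonyl unit or the two methyl groups on its nitrogen account for this rise, and an unsubstituted sulfonamide, a chlorine or a carboxylic acid on this carbon could help to separate these possibilities. They also leave open whether dimethylsulfamoyl would have the same effect with methoxy in place of the ethoxy group, and where, between the number of compound 2 and the limit of compound 3, any other replacement would fall.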